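This account rests on a few compounds, and the source may have more. Where it says the series, first, only, none or still open, it means among the compounds named here.

Measured in an ADME assay on microsomes from liver (Homo sapiens) for metabolic stability; a lower number here means that the compound disappears faster, a higher number that the compound lasts longer:
Compound 1 `CC#C[C@@H](Cc1nnn[nH]1)c1ccc(OCc2ccc3sc(F)c(-c4ccccc4C)c3c2)cc1`: 0.0667 h
Compound 2 `CC#C[C@@H](Cc1nnn[nH]1)c1ccc(OCc2ccc3sc(C)c(-c4ccc(OCCOC)cc4C)c3c2)cc1`: 1.48 h
Compound 3 `CC#C[C@@H](Cc1nnn[nH]1)c1ccc(OCc2ccc3scc(-c4ccc(OCCOC)cc4C)c3c2)cc1`: 0.717 h

Compound 3 is second highest of the three numbers, with compound 2 above it and compound 1 below it, both gaps beyond the scatter. Compound 4 `CC#C[C@@H](Cc1nnn[nH]1)c1ccc(OCc2ccc3sc(F)c(-c4ccc(OCCOC)cc4C)c3c2)cc1` has fluoro in place of hydrogen on an aromatic carbon, next to the ring sulfur: fluoro in place of hydrogen on an aromatic carbon. For the measured compounds named here, the one measured step at this carbon is modest: a 2.1-fold lower number from compound 2 to compound 3 (0.31 log units; beyond the scatter). Compound 1 also has fluoro there, but not the 4-(2-methoxyethoxy)-2-methylphenyl group, so its 0.0667 h gives no matched comparison. In this assay a small upward step is expected, possibly none beyond the scatter: the estimate is a 1.3-fold higher number from compound 3 to compound 4 (0.10 log units; within the scatter). For compound 4 the estimated half-life is 0.9 h, with an expected range of 0.35 h to 2 h.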

Compound 4, half-life: 1.95 h
Compound 4: middle estimate off by 2.2-fold (0.34 log units), on the low side; measured number inside the range.
By their numbers in this assay, from the lowest: compound 1; then compound 3; then compounds 2 and 4 (each within the scatter of the next).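

In this assay, for the compounds shown here, fluoro in place of hydrogen on this aromatic carbon, next to the ring sulfur, gives a 2.7-fold higher number from compound 3 to compound 4 (0.43 log units; beyond the scatter) as the first matched step for fluoro here, while fluoro in place of methyl gives a 1.3-fold higher number from compound 2 to compound 4 (0.12 log units; within the scatter) and leaves the two groups unseparated. With fluoro held constant, the gain of a 2-methoxyethoxy group gives a 29-fold higher number from compound 1 to compound 4 (1.47 log units; beyond the scatter) as the largest step among these compounds. No evidence at hand accounts for either effect. Open, going by these compounds, is whether chloro or a nitrile at this carbon would match fluoro and methyl, and whether an amine or a longer chain in place of 2-methoxyethoxy would keep the half-life.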